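The compounds below may be only part of what the source reports. "The series", "measured", "known", "first", "only" and "open" are said of these compounds alone.

In an ADME assay on 3T3-L1 cells (Mus musculus) for cytotoxicity, read by luminescence and CellTiter-Glo, with a stated time of 72 h (on this read-out lower numbers stand for an effect already at smaller amounts and higher numbers for an effect only at larger amounts of compound), compound 1 `C=C1CC[C@@]2(C(OC)[C@@H]1O)[C@@H](C(=O)O)CC[C@H]2C(C)C` gives > 500000 nM, which is a limit and not a number. Compound 2 `C=C1CC[C@@]2(C[C@@H]1OC(C)=O)[C@@H](C(=O)O)CC[C@H]2C(C)C` gives > 500000 nM, also a limit. Compound 3 `C=C1CC[C@@]2(C[C@@H]1O)[C@@H](C(=O)O)CC[C@H]2C(C)C` gives > 500000 nM, again a limit, so it has no number of its own. Within the data shown here, all the values so far sit at one point: the limit of > 500000 nM in this assay, at which 3 of the 3 values shown sit.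

Compound 4 `C=C1CC[C@]2(C[C@@H]1O)[C@H](C)CC[C@@H]2C(=O)O` differs from compound 3 by methyl in place of isopropyl on a saturated ring carbon; in words, methyl in place of isopropyl on a saturated ring carbon.

Two measured steps lead to compound 3: a step that the two limits leave unreadable from compound 1 to compound 3 and a step that the two limits leave unreadable from compound 2 to compound 3. Neither has a readable size, and neither involves isopropyl, so they offer no size to carry over. Among the measured compounds shown here, they show only that all three compounds stay at the limit, and a step beyond the scatter is not expected in this assay, in either direction.

The estimated change is a number no higher from compound 3 to compound 4 (the limit leaves the size open). For compound 4 the estimate is 500000 nM, with an expected range of 250000 nM to 1000000 nM.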

Compound 4, half-maximal effective concentration: > 500000 nM
Compound 4 was reported as a limit; the forecaster's own chance of this, stated with the estimate: 85%; the middle value sits exactly at the limit.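

No step can be read between compound 3 and compound 4, since both are reported only as a limit: the limit of > 500000 nM in this assay, at which 4 of the 4 values shown sit.

The compounds shown leave open where any of them would give an actual number in this assay, and whether methyl and isopropyl differ there at all.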